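Methoxy removal on the aryl piperazine, second core variant

A few compounds are considered here, and "the series" means these few. Any claim that something is new, unique, unknown or untested is made for them only; others in the source may bear on it.

compound 1, `COc1cc(OC)cc(N2CCN(C(=O)c3oc(C)nc3-c3ccc(F)cc3)CC2)c1`, in a functional assay on HL-60 cells (Homo sapiens) for inhibition, read by MTT assay, with a stated time of 72 h; a lower number here means a stronger inhibitor, a higher number a weaker inhibitor: 38.5 nM
compound 2, `COc1cccc(N2CCN(C(=O)c3oc(C)nc3-c3ccc(F)cc3)CC2)c1`, in this assay: 112 nM
compound 3, `COc1cc(OC)cc(N2CCN(C(=O)c3oc(C)nc3-c3cccc(F)c3)CC2)c1`, in this assay: 28.2 nM

Two cores are compared. Compound 1 and compound 3 differ in 3-fluorophenyl in place of 4-fluorophenyl on an aromatic carbon, and in this assay this gave a 1.4-fold lower number from compound 1 to compound 3 (0.14 log units; within the scatter). Among the measured compounds shown here, on the first core, the change hydrogen in place of methoxy on an aromatic carbon gave a 2.9-fold higher number from compound 1 to compound 2 (0.46 log units; beyond the scatter), the only measured instance of this change.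

Compound 4, `COc1cccc(N2CCN(C(=O)c3oc(C)nc3-c3cccc(F)c3)CC2)c1`, has not yet been measured. It differs from compound 3 by hydrogen in place of methoxy on an aromatic carbon, which is the same change, at a place described in identical terms. For the measured compounds named here, from compound 3 to compound 4 a step of a 2.8-fold higher number from compound 3 to compound 4 (0.45 log units; beyond the scatter) is expected in this assay, resting on the single earlier instance a 2.9-fold higher number from compound 1 to compound 2 (0.46 log units; beyond the scatter) and on the closeness of the two cores. For compound 4 the estimate is 80 nM, with a range from 40 nM to 160 nM.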

Compound 4, half-maximal inhibitory concentration: "not active" (no number reported)
Compound 4: no number reported, and the estimate cannot be compared.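

Among the compounds shown here, compound 4 is reported as "not active" in this assay, without a number, and no step from compound 3 can be read. The compounds shown leave open how large that step is, and nothing given bears on the reason for this result.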